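The compounds below may be only part of what the source reports. "The series", "measured", "known", "first", "only" and "open" are said of these compounds alone.

Three compounds have been measured in a functional assay on DLD-1 cells (Homo sapiens) for cytotoxicity, with a stated time of 48 h; a higher number here means a weaker inhibitor, a lower number a stronger inhibitor:

compound 1, `Cc1ccc2c(=O)cc(/C=C/[S+](C)[O-])oc2c1`: 7000 nM
compound 2, `CCCCC(=O)Oc1ccc2oc(/C=C/[S+](C)[O-])cc(=O)c2c1`: 6700 nM
compound 3, `COc1cccc2c(=O)cc(/C=C/[S+](C)[O-])oc12`: 9000 nM

All three share the same core and differ only in what hangs on it. Compound 2 shows the lowest of the three numbers, but its gaps to compound 1 and to compound 3 both lie within the usual scatter of this assay, so the three cannot be ranked against one another; they sit together in one band.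

The next compound is compound 4, `CC(C)Oc1ccc2oc(/C=C/[S+](C)[O-])cc(=O)c2c1`, which has not yet been measured. It differs from compound 2 in one place:

isopropyl in place of butylcarbonyl on an oxygen on an aromatic ring

Within the data shown here, no measured pair differs at just this point, so nothing shows directly what this change does. What the data do show is that three different groups on the core all give numbers within the scatter of each other. On that basis the step is expected to be small, none beyond the scatter: a 1.1-fold higher number from compound 2 to compound 4 (0.05 log units; within the scatter). Compound 4 is estimated at 7500 nM, with a range from 3000 nM to 20000 nM.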

Compound 4, half-maximal inhibitory concentration: 8000 nM
Estimate against measurement, compound 4: 1.1-fold (0.03 log units) below, within the range that was stated.
By their numbers in this assay, from the lowest: compounds 2, 1, 4 and 3 (each within the scatter of the next).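

In this assay, isopropyl in place of butylcarbonyl on an oxygen on an aromatic ring gives a 1.2-fold higher number from compound 2 to compound 4 (0.08 log units; within the scatter), the first step read directly at this position. At this oxygen, the assay does not separate a group of 6 heavy atoms that holds a double bond and a hydrogen-bond acceptor from one of 3 carbon atoms with neither, so the ester link and the larger group are not needed to keep the number in this band. Nothing in the data accounts for how closely the two compounds agree.

As far as these compounds go, whether any group on this oxygen can move the number beyond the scatter remains open. A bare hydroxyl, a chain ending in an amine or one ending in a carboxylic acid could each test this.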